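The compounds below may be only part of what the source reports. "The series", "measured", "known", "first", "only" and "open" are said of these compounds alone.

Working notes on the series.

Compound 1 `COC(=O)[C@H]1C[C@H]2CNC[C@H]2C1` gives 14000 nM in an assay on CHO cells for agonist activity at Neuronal acetylcholine receptor; alpha3/beta4 (Homo sapiens), read by FLIPR and calcium flux; a lower number here means that less compound is needed, a higher number that more compound is needed for the effect. Compound 2 `CNC(=O)[C@H]1C[C@H]2CNC[C@H]2C1` carries a methylamino group on the same carbonyl carbon; for compound 2 the result in this assay is "not determined" (no result reported), so it adds nothing to the numbers. Compound 3 `O=C(C1CC1)[C@H]1C[C@@H]2CNC[C@@H](C2)C1` is built on a larger core and gives 1300 nM in this assay; this is the lowest of the two numbers reported, and the gap to compound 1 is beyond the scatter. Among the measured compounds shown here, no single-change step between measured compounds is available, so the effect of varying the group on the carbonyl carbon is not known from any measured pair.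

Compound 4 `CC(C)NC(=O)[C@H]1C[C@@H]2CNC[C@@H](C2)C1` keeps the core of compound 3 and differs only by isopropylamino in place of cyclopropyl on a carbonyl carbon. For the measured compounds named here, the exchange of a ketone for an amide has no measured precedent, and compound 2, which would have offered a hint, carries no number. A step in this assay of modest size toward a higher number is expected, but the scatter could cover it. The step from compound 3 to compound 4 is expected to be a 1.9-fold higher number from compound 3 to compound 4 (0.28 log units; within the scatter). Compound 4 is estimated at 2500 nM in this assay, with a range from 600 nM to 10000 nM.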

Compound 4, half-maximal effective concentration: 27000 nM
Compound 4: middle estimate off by 11-fold (1.03 log units), on the low side, outside the stated range (above it).
By their numbers in this assay, from the lowest: compound 3; then compounds 1 and 4 (each within the scatter of the next).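

Among the compounds shown here, on the core shared by compound 3 and compound 4, the group on a carbonyl carbon whose other neighbour is a saturated ring carbon clearly matters in this assay: isopropylamino in place of cyclopropyl gives a 21-fold higher number from compound 3 to compound 4 (1.32 log units; beyond the scatter), and this is the first measured single-change step. The exchange turns a ketone into an amide, opens the three-membered ring into a chain, and brings in a nitrogen and a hydrogen-bond donor, so this one step cannot separate these features from one another. Nothing available explains the size of the step.

The compounds shown leave open whether the step follows the entering nitrogen or the lost ring: isopropyl on the carbonyl carbon, or cyclopropylamino in the same place, would pull the two apart on this core. Also open, as far as these compounds go, is how methoxy or methylamino on the carbonyl carbon reads on this core, as compound 1 and compound 2 carry those groups on a different core.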